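Dimethylamino on the N-phenyl ring of the shared core

This account rests on a few compounds, and the source may have more. Where it says the series, first, only, none or still open, it means among the compounds named here.

Measured compounds in a functional assay on MCF7 cells (Homo sapiens) for cytotoxicity, read by MTT assay, with a stated time of 72 h; on this read-out lower numbers stand for stronger inhibition and higher numbers for weaker inhibition:
compound 1 `O=C1CS/C(=N\c2csc(-c3ccc(Cl)cc3)c2)N1`: > 50000 nM
compound 2 `O=C1CS/C(=N\c2csc(-c3ccc(Cl)cc3)c2)N1c1ccccc1`: > 50000 nM

Compound 1 `O=C1CS/C(=N\c2csc(-c3ccc(Cl)cc3)c2)N1` reaches only the limit of this assay, > 50000 nM. Compound 2 `O=C1CS/C(=N\c2csc(-c3ccc(Cl)cc3)c2)N1c1ccccc1` likewise stops at the limit, > 50000 nM. The step that the two limits leave unreadable from compound 1 to compound 2 therefore cannot be read; both values sit at the limit of > 50000 nM in this assay, at which 2 of the 2 values shown sit.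

Compound 3 `CN(C)c1ccc(N2C(=O)CS/C2=N\c2csc(-c3ccc(Cl)cc3)c2)cc1` carries dimethylamino in place of hydrogen on an aromatic carbon. Within the data shown here, no measured step bears on this change, and compound 2 itself is known only as a limit. Compound 3 is thus expected near that limit, with a step that the limit leaves unreadable from compound 2 to compound 3 beyond the scatter not foreseen. The estimate for compound 3 is 60000 nM, range 15000 nM to 250000 nM.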

Compound 3, half-maximal inhibitory concentration: > 50000 nM
Compound 3: only a limit was reported (the forecaster's own chance of this, stated with the estimate: 75%); the middle value lies beyond the limit too.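

Compound 3 also stops at a limit in this assay, > 50000 nM, so no step from compound 1 or compound 2 to compound 3 can be read: the limit of > 50000 nM in this assay, at which 3 of the 3 values shown sit.

Open remains whether any change on the shared core brings a value inside that limit.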